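Aminothiazolopyrimidine series: pyrrolidinylcarbonyl in place of methyl

This account rests on a few compounds, and the source may have more. Where it says the series, first, only, none or still open, it means among the compounds named here.

Measured compounds:
- compound 1, `CS(=O)(=O)c1ccccc1Nc1nc2c(Nc3ccc(C(F)(F)F)cc3)ncnc2s1`: 221 nM
- compound 2, `FC(F)(F)c1ccc(Nc2ncnc3sc(Nc4ccccc4C(F)(F)F)nc23)cc1`: 37 nM
- compound 3, `Cc1ccc(Nc2ncnc3sc(Nc4c(Cl)cccc4Cl)nc23)cc1`: 32 nM

All three share one core and differ in the two aryl amine substituents. In a functional assay on HEK293 cells for antagonist activity at transient receptor potential cation channel subfamily V member 1 (Rattus norvegicus), read by calcium flux (a higher number here means a weaker inhibitor, a lower number a stronger inhibitor), compound 3 gives the lowest of the three numbers. Its nearest neighbour is compound 2, and the gap between them lies within the scatter, so no order between compound 3 and compound 2 is claimed. The gap to compound 1 is beyond the scatter.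

Going by the values given here, the one measured step, a 6.0-fold lower number from compound 1 to compound 2 (0.78 log units; beyond the scatter), concerns the other aryl amine of the core and not the ring that is changed here.

Compound 4, `O=C(c1ccc(Nc2ncnc3sc(Nc4c(Cl)cccc4Cl)nc23)cc1)N1CCCC1`, differs from compound 3 as follows: (pyrrolidin-1-yl)carbonyl in place of methyl on an aromatic carbon. Among the compounds with values here, no measured step touches this position, so the change cannot be anchored to a precedent in this assay. Within the data shown here, since the only known step on this series is of modest size, a step of similar magnitude or smaller is expected here, in either direction, with the larger likelihood of a somewhat higher number; compound 4 is expected to be close to compound 3, with a 1.9-fold higher number from compound 3 to compound 4 (0.27 log units; within the scatter). For compound 4 the estimate in this assay is 60 nM, with a range from 20 nM to 200 nM.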

Compound 4, half-maximal inhibitory concentration: > 5000 nM
Compound 4: no number, only a limit; the forecaster's own chance of this, stated with the estimate: 5%; middle value at least 83-fold (1.92 log units) from the limit.
By their numbers in this assay, from the lowest: compounds 3 and 2 (each within the scatter of the next); then compound 1. At a limit, above all of these: compound 4.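

Compound 4 has no number in this assay, only a limit of the assay: the limit of > 5000 nM in this assay, at which 1 of the 4 values shown sits. Going by these compounds alone, the step at this position, an at least 150-fold higher number from compound 3 to compound 4 (2.19 log units; beyond the scatter), is large, whereas the only earlier step, a 6.0-fold lower number from compound 1 to compound 2 (0.78 log units; beyond the scatter), is modest and lies on the other aryl amine of the shared core, so it gave no reading here. Within the data shown here, the position on the ring carrying the methyl of compound 3 is therefore not indifferent to substitution: at least for (pyrrolidin-1-yl)carbonyl in place of methyl, the change alone takes the compound from among the lowest numbers of the series to the limit, a sensitivity that the earlier compounds could not reveal.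

This single change does not separate the contribution of the carbonyl from that of the pyrrolidine ring, and the limit does not tell how far the true value of compound 4 lies from compound 3. A primary amide, a dimethylamide, a carboxylic acid, a methoxy group or a longer alkyl chain at this position would show whether the loss follows the carbonyl, the ring or any larger group.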